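The compounds below may be only part of what the source reports. "The series", "measured", "known", "first", "only" and "open" are said of these compounds alone.

Compound 1, `CCCNC(=O)Nc1nc2ccc(-c3cnc(OC)c(NS(=O)(=O)c4ccc(F)cc4)c3)cn2n1`: 420 nM.
Compound 2, `COc1ncc(-c2ccc3nc(NC(=O)NC4CC4)nn3c2)cc1NS(=O)(=O)c1ccc(F)cc1`: 540 nM.
Compound 3, `COc1ncc(-c2ccc3nc(NC(=O)NCCN4CCN(C)CC4)nn3c2)cc1NS(=O)(=O)c1ccc(F)cc1`: 760 nM.

All three were read in a functional assay on U-87MG ATCC cells for cytotoxicity against U-87 MG (Homo sapiens), read by MTT assay, with a stated time of 72 h; a lower number here means a stronger inhibitor, a higher number a weaker inhibitor. Compound 1 shows the lowest of the three numbers, yet its steps to the others, a 1.3-fold higher number from compound 1 to compound 2 (0.11 log units; within the scatter) and a 1.8-fold higher number from compound 1 to compound 3 (0.26 log units; within the scatter), stay within the scatter, as does a 1.4-fold higher number from compound 2 to compound 3 (0.15 log units; within the scatter). Compound 4, `COc1ncc(-c2ccc3nc(NC(=O)NCCN4CCCCC4)nn3c2)cc1NS(=O)(=O)c1ccc(F)cc1`, differs from compound 1 by piperidin-1-yl in place of methyl on a saturated chain carbon, two bonds along the chain from an amide-type nitrogen. The step that bears most on this is a 1.8-fold higher number from compound 1 to compound 3 (0.26 log units; within the scatter), where a different saturated ring enters at the same place; the two remaining steps are also small. No movement beyond the scatter is therefore expected. For compound 4 the expected step is a 1.4-fold higher number from compound 1 to compound 4 (0.15 log units; within the scatter). Compound 4 is estimated at 600 nM, within 300 nM to 1200 nM.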

Compound 4, half-maximal inhibitory concentration: 1080 nM
For compound 4 the middle estimate is 1.8-fold (0.26 log units) below the measured one, within the range that was stated.
By their numbers in this assay, from the lowest: compounds 1, 2, 3 and 4 (each within the scatter of the next, the first and the last beyond it).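

Placing piperidin-1-yl on the saturated chain carbon gives the only step beyond the scatter so far, a 2.6-fold higher number from compound 1 to compound 4 (0.41 log units; beyond the scatter), and it is modest. The same group stays within the scatter of the other two compounds, with a 1.4-fold higher number from compound 3 to compound 4 (0.15 log units; within the scatter) and a 2.0-fold higher number from compound 2 to compound 4 (0.30 log units; within the scatter), so only compound 1 and compound 4 separate here. No measured evidence accounts for this step. The compounds shown leave open whether morpholin-4-yl or an open-chain dimethylamino group in the same place would stay with compound 1 or compound 4.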